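The compounds below may be only part of what the source reports. "The series", "measured", "known", "first", "only" and "open" are said of these compounds alone.

Measured in a functional assay on the whole organism for positive allosteric modulation, with Mus musculus as the target; on this read-out higher numbers stand for an effect only at larger amounts of compound and lower numbers for an effect already at smaller amounts:
- compound 1 `CCC(=O)N(c1ccc(Cl)c(Cl)c1)C1CCCC1N(CC)CC`: 0.1 mg/kg
- compound 2 `CCCN(CCC)C1CCCC1N(C(=O)CC)c1ccc(Cl)c(Cl)c1`: 2 mg/kg

Compound 2, at 2 mg/kg, holds the higher of the two numbers in this assay, so its effect appears only at a larger dose than that of compound 1. Compound 3 `CCC(=O)N(c1ccc(Cl)c(Cl)c1)C1CCCC1N(C)CCN(C)C` keeps the rest of compound 2 and differs at the amine: (2-(dimethylamino)ethyl)(methyl)amino in place of dipropylamino on a saturated ring carbon. For the measured compounds named here, one measured step bears on this place. Dipropylamino in place of diethylamino gave a 20-fold higher number from compound 1 to compound 2 (1.30 log units; beyond the scatter), a large step, so the read-out is clearly sensitive to the amine group here. Going by the values given here, that step does not transfer directly, since no measured compound carries (2-(dimethylamino)ethyl)(methyl)amino, and its direction for the new group remains open. The expectation is therefore no clear shift from the higher number, with wide uncertainty on both sides. The expected change is a 1.5-fold higher number from compound 2 to compound 3 (0.18 log units; within the scatter), which is only an estimate. In this assay the estimated value for compound 3 is 3 mg/kg, with an expected range from 0.5 mg/kg to 20 mg/kg.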

Compound 3, dose for half-maximal effect: 0.8 mg/kg
Beside the measured number, compound 3's estimate is 3.8-fold (0.57 log units) above it; the measured number falls inside the stated range.
By their numbers in this assay, from the lowest: compound 1; then compound 3; then compound 2.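

In this assay, replacing dipropylamino with (2-(dimethylamino)ethyl)(methyl)amino gives a 2.5-fold lower number from compound 2 to compound 3 (0.40 log units; beyond the scatter) and so shows that a group as large as dipropylamino by heavy-atom count can sit at this saturated ring carbon with a smaller number, the entering group having one carbon exchanged for a nitrogen and 2 hydrogen-bond acceptors against 1. Heavy-atom count alone therefore does not fix the read-out at this place, although the comparison rests on this single pair. Diethylamino still holds the lowest number of the three amines, as the change to the new group gives an 8.0-fold higher number from compound 1 to compound 3 (0.90 log units; beyond the scatter) and leaves that group between the two dialkylamino groups; no accompanying measurement accounts for either shift.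

The compounds shown leave open whether a shorter amine such as dimethylamino would fall further or rise, which would test whether diethylamino sits near a minimum in this short series. They also leave open whether the gain tracks the second nitrogen itself, a question that a piperazine at this carbon, or a hydroxyl in place of the terminal dimethylamino, would address.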